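The source may hold more compounds than are shown below. What is called first, only, known or untested is meant among the compounds shown, and "the series" means these compounds.

In a functional assay on K562 cells (Homo sapiens) for inhibition, read by trypan blue exclusion, with a stated time of 48 h (a higher number here means a weaker inhibitor, a lower number a stronger inhibitor), compound 1 `Cc1ccccc1/C=C/C(=O)Nc1ccc(Cl)cc1C(N)=O` gives 9500 nM and compound 2 `Cc1ccc(/C=C/C(=O)Nc2ccc(Cl)cc2C(N)=O)cc1` gives 6300 nM. These two values lie within the scatter of each other, so compound 2 stands level with compound 1 and neither can be ranked ahead. Compound 3 `Cc1ccc(/C=C/C(=O)Nc2ccc(I)cc2C(N)=O)cc1` keeps the structure of compound 2 except for one change: iodo in place of chloro on an aromatic carbon. In words, this is iodo in place of chloro on an aromatic carbon, meta to a carbamoyl group. Going by the values given here, the only measured step, a 1.5-fold lower number from compound 1 to compound 2 (0.18 log units; within the scatter), swaps 2-methylphenyl for 4-methylphenyl and leaves the chloro untouched. Among the compounds with values here, it therefore says little about this change, and no measured pair varies the halogen. With so little guidance, only a modest shift is expected, and its direction is uncertain: a 2.1-fold lower number from compound 2 to compound 3 (0.32 log units; beyond the scatter). For compound 3 the estimated value is 3000 nM, with an expected range from 600 nM to 10000 nM.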

Compound 3, half-maximal inhibitory concentration: > 10000 nM
Compound 3: no number, only a limit; the forecaster's own chance of this, stated with the estimate: 3%; middle value at least 3.3-fold (0.52 log units) away from the limit.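

Going by these compounds alone, this is the first measured change of the halogen on this aromatic carbon, meta to a carbamoyl group, and it gives an at least 1.5-fold higher number from compound 2 to compound 3 (0.20 log units; that floor lies within the scatter). In this assay compound 3 gives > 10000 nM, which is a limit of the assay and not a number. Iodo in place of chloro therefore brings no stronger inhibition at this position, but the true size of the change remains unknown, and the comparison rests on a single limit: the limit of > 10000 nM in this assay, at which 1 of the 3 values shown sits.

The compounds shown leave open how fluoro, bromo or an amine would read on this same carbon, and so whether any halogen is needed there. Also open, as far as these compounds go, is whether iodo would act on the 2-methylphenyl compound 1 as it does on the 4-methylphenyl compound 2.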